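This account rests on a few compounds, and the source may have more. Where it says the series, first, only, none or still open, it means among the compounds named here.

Compound 1 `O=C(CCCCCCNC(=O)C(O)(O)C(F)(F)F)Nc1cccc(Br)c1` carries a 3-bromophenyl group on an amide-type nitrogen. For the measured compounds named here, in a functional assay on HCT-116 cells (Homo sapiens) for inhibition, read by colorimetric assay, with a stated time of 3 days (on this read-out higher numbers stand for weaker inhibition and lower numbers for stronger inhibition), compound 1 gives 3060 nM, the only plain number among the three values measured. Compound 2 `C/C(=N\O)C(=O)NCCCCCC(=O)Nc1ccccc1` reaches only a limit in this assay, > 100000 nM. Compound 3 `O=C(CCCCCCNC(=O)C(O)(O)C(F)(F)F)Nc1ccc(C(=O)c2ccccc2)cc1` likewise stops at a limit in this assay, > 40000 nM. Compound 4 `O=C(CCCCCCNC(=O)C(O)(O)C(F)(F)F)Nc1c(F)cc(F)cc1F` keeps the core of compound 1 and differs in one place: 2,4,6-trifluorophenyl in place of 3-bromophenyl on an amide-type nitrogen. Going by the values given here, no measured pair here shows such a swap, so the size of this step cannot be read from the data. A modest loss of inhibition, beyond the usual scatter, is expected, and the estimated step is a 2.9-fold higher number from compound 1 to compound 4 (0.47 log units; beyond the scatter). Compound 4 is therefore expected to give about 9000 nM in this assay, within a range from 2500 nM to 40000 nM.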

Compound 4, half-maximal inhibitory concentration: 22200 nM
For compound 4 the middle estimate is 2.5-fold (0.39 log units) below the measured one, and the stated range covers the measured number.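

In this assay, for the compounds shown here, the swap gives a 7.3-fold higher number from compound 1 to compound 4 (0.86 log units; beyond the scatter) and so shows, for the first time here, that the group on this amide-type nitrogen can change the read-out beyond the usual scatter. Both groups hold one six-membered aromatic ring of carbon only and no hydrogen-bond donors or acceptors, so those shared counts do not keep the number in place. Nothing measured here gives a reason for this step.

The compounds shown do not separate losing the bromine from gaining the fluorines. Going by these compounds, how an amine or a carboxylic acid on this ring, or a longer chain, would move the number also stays open.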